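The source may hold more compounds than are shown below. What is called first, only, known or untested is meant among the compounds shown, and "the series" means these compounds.

Measured in a functional assay on HeLa cells (Homo sapiens) for antiproliferative activity, read by CCK-8 assay, with a stated time of 72 h, tested at 8 uM; a lower number here means a weaker effect, a higher number a stronger effect of the compound at the concentration tested:

compound 1 `Nc1ccccc1NC(=O)c1ccc(CSC(=S)N2CCN(Cc3ccccn3)CC2)cc1`: 61.4%
compound 2 `Nc1ccccc1NC(=O)c1ccc(CSC(=S)N2CCc3ccccc32)cc1`: 67%
compound 3 `Nc1ccccc1NC(=O)c1ccc(CSC(=S)N2CCN(c3ccc(F)cc3)CC2)cc1`: 64.5%

The three numbers lie close together. Compound 1 has the lowest figure of the three, but the step of a number 3.1 percentage points higher from compound 1 to compound 3 (within the scatter) is within the scatter, and the gap between compound 1 and compound 2 is likewise within the scatter, so none of the three can be set apart from the others on these data.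

Compound 4 `Nc1ccccc1NC(=O)c1ccc(CSC(=S)N2CCN(Cc3ccccc3)CC2)cc1` is not yet measured in this assay. It differs from compound 1 as follows: phenyl in place of pyridin-2-yl on a saturated chain carbon bound to an amine nitrogen in a ring

Going by the values given here, the only measured step that bears on this change is the one from compound 1 to compound 3, which also alters the group on the ring amine nitrogen, though by a different swap; that step, a number 3.1 percentage points higher from compound 1 to compound 3 (within the scatter), did not leave the scatter. Nothing in the series shows that a change at this position moves this assay beyond the scatter, so the expected step of a number 1.6 percentage points higher from compound 1 to compound 4 (within the scatter) is small and of no clear direction. Compound 4 is estimated at 63%, with a range of 52% to 74%.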

Compound 4, a percentage reported as inhibition, at one concentration (the size of the read-out at that concentration, not a potency): 31.3%
Compound 4: middle estimate off by 31.7 percentage points, on the high side; the measured number lies below the stated range.
By their numbers in this assay, from the lowest: compound 4; then compounds 1, 3 and 2 (each within the scatter of the next).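

In this assay, phenyl in place of pyridin-2-yl on a saturated chain carbon bound to an amine nitrogen in a ring gives a number 30.1 percentage points lower from compound 1 to compound 4 (beyond the scatter), so this position does respond, even where only the ring nitrogen of pyridin-2-yl gives way to carbon. Benzyl in place of 4-fluorophenyl on the amine nitrogen in the ring gives a number 33.2 percentage points lower from compound 3 to compound 4 (beyond the scatter), so the closeness of the earlier compounds does not extend to every group at this nitrogen. No available evidence accounts for the difference.

On these data alone, whether the effect is specific to pyridin-2-yl remains open, and pyridin-3-yl or pyridin-4-yl on the same chain carbon would address that. A longer chain carrying the phenyl, or a methoxy or hydroxyl on the phenyl of the benzyl group, would show how far the lower figure of compound 4 extends.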